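Inverting one stereocentre on the core: rat clearance

This account rests on a few compounds, and the source may have more. Where it says the series, first, only, none or still open, it means among the compounds named here.

Compound 1 `CC[C@H](C)[C@@H]1C(=O)N[C@H](C2Cc3ccccc3C2)C(=O)N1[C@@H](C(=O)N(C)C)c1ccc(C)[n+]([O-])c1` gives 28 mL/min/kg in an in vivo ADME assay on the whole organism for pharmacokinetics, with Rattus norvegicus as the target, at a dose of 5 mg/kg; a higher number here means faster removal of the compound, a lower number slower removal. Compound 2 `CC[C@H](C)[C@@H]1C(=O)N[C@H](C2Cc3ccccc3C2)C(=O)N1[C@@H](C(=O)N(C)C)c1ccc(C)nc1C` gives 15 mL/min/kg in this assay, and the change a 1.9-fold lower number from compound 1 to compound 2 (0.27 log units; within the scatter) stays within the usual scatter. Compound 3 `CC[C@H](C)[C@@H]1C(=O)N[C@H](C2Cc3ccccc3C2)C(=O)N1[C@@H](C(=O)N1CCOCC1)c1ccc(C)nc1` gives 27 mL/min/kg in this assay; it stands second highest of the three, its number lying nearer to compound 1 than to compound 2, though both gaps fall within the scatter.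

Compound 4 `CC[C@@H](C)[C@@H]1C(=O)N[C@H](C2Cc3ccccc3C2)C(=O)N1[C@@H](C(=O)N1CCOCC1)c1ccc(C)nc1` has not yet been measured. Compared with compound 3, (the two compounds have the same atoms and bonds and differ only in configuration as drawn: 1 of 4 stereo elements differ; a stereocentre at a saturated chain carbon is drawn S in compound 3 and R in compound 4). For the measured compounds named here, none of the measured steps involves a change of configuration, so no measured step bears directly on it; the one available step, a 1.9-fold lower number from compound 1 to compound 2 (0.27 log units; within the scatter), exchanged an aromatic ring and stayed within the scatter. With nothing in the data pointing to a shift in either direction, the step the writer expects, no change at the digits printed from compound 3 to compound 4 (within the scatter), is none beyond the scatter. The writer estimates compound 4 at 27 mL/min/kg in this assay, within a range from 13 mL/min/kg to 55 mL/min/kg.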

Compound 4, clearance: 39 mL/min/kg
For compound 4 the middle estimate is 1.4-fold (0.16 log units) below the measured one; the range from low to high includes it.
By their numbers in this assay, from the lowest: compounds 2, 3, 1 and 4 (each within the scatter of the next, the first and the last beyond it).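

In this assay, for the compounds shown here, inverting the saturated chain carbon gives a 1.4-fold higher number from compound 3 to compound 4 (0.16 log units; within the scatter), the only step here that touches configuration rather than a group. At this position, drawn S in compound 3 and R in compound 4, the clearance of the morpholine amide series therefore shows no difference that can be told from the usual scatter. The step can be read for this one stereocentre alone because nothing else separates the pair: the fact that compounds 3 and 4 differ only in the configuration as drawn

The compounds shown leave open whether the same inversion would stay within the scatter with the dimethyl amide of compound 1 or the dimethylpyridine of compound 2, and what inverting the other three stereo elements would do. They also leave open how clearance would respond if a longer chain or a carboxylic acid stood at this carbon.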